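An Oxime Ether in Place of the Oxadiazole

The compounds below may be only part of what the source reports. "The series", "measured", "known", "first", "only" and "open" are said of these compounds alone.

Compound 2 `Cc1noc(-c2ccccc2NCC2=NCCN2)n1` carries a 3-methyl-1,2,4-oxadiazol-5-yl group on the shared core. In a functional assay for activation of Alpha-1B adrenergic receptor (Homo sapiens), read by calcium flux (on this read-out lower numbers stand for an effect already at smaller amounts and higher numbers for an effect only at larger amounts of compound), compound 2 gives only a limit, < 5020 nM, and no number. Its neighbour compound 1 `c1csc(-c2ccccc2NCC2=NCCN2)c1` bears thiophen-2-yl at the same place, and in this assay compound 1 gives 5.75 nM. Among the compounds with values here, the single step connecting the two, a step that the limit leaves unreadable from compound 1 to compound 2, cannot be sized since one of its two values is the limit (the limit of < 5020 nM in this assay, at which 1 of the 2 values shown sits). Compound 3 `CO/N=C(\C)c1ccccc1NCC1=NCCN1` is not yet measured. It differs from compound 2 by a group of 5 heavy atoms (3 carbon, 1 nitrogen, 1 oxygen; no ring) in place of a group of 6 heavy atoms (3 carbon, 2 nitrogen, 1 oxygen; one five-membered aromatic ring with 3 hetero atoms), on an aromatic carbon. No measured step covers this change: the only step shown starts from the same limit and leaves its size open, so there is nothing to carry over, and the pair of compound 1 and compound 2 shows only that the thiophen-2-yl compound has a readable number while the oxadiazole compound has a limit. The expectation for compound 3 is therefore held loosely, with the step that the limit leaves unreadable from compound 2 to compound 3 as a rough guess. Compound 3 is estimated at 300 nM, within 30 nM to 3000 nM.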

Compound 3, half-maximal effective concentration: < 5020 nM
Compound 3 was reported as a limit; the forecaster's own chance of this, stated with the estimate: 25%; the middle value lies beyond the limit too.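

In this assay compound 3 gives < 5020 nM as a limit and no number, so no new step can be read among compound 1, compound 2 and compound 3: the limit of < 5020 nM in this assay, at which 2 of the 3 values shown sit.

The compounds shown leave open how far compound 2 and compound 3 lie from compound 1, and whether those two differ from each other at all.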